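The source may report more compounds than this note shows. Statements on the series, on what has been measured and on what is new or still open speak of the compounds shown alone.

Measured in a functional assay on PC-3 cells (Homo sapiens) for antiproliferative activity, read by MTT assay, with a stated time of 72 h; a lower number here means a stronger inhibitor, a higher number a weaker inhibitor:
Compound 1 `Cc1ccc(-c2c(CN3CCCCC3)nc3scc(C(=O)O)n23)cc1`: 16600 nM
Compound 2 `CCC(=O)NNC(=O)c1csc2ncc(-c3ccc(C)cc3)n12`: 18500 nM
Compound 3 `CCCC(=O)NNC(=O)c1csc2ncc(-c3ccc(C)cc3)n12`: 53500 nM

In this assay, compound 3 at 53500 nM carries the highest number of the three. Compound 4 `CCCC(=O)NNC(=O)c1csc2ncc(-c3ccc(OC)cc3)n12` differs from it in one place: methoxy in place of methyl on an aromatic carbon, turning 4-methylphenyl into 4-methoxyphenyl. Going by the values given here, the only measured step, a 2.9-fold higher number from compound 2 to compound 3 (0.46 log units; beyond the scatter), is modest and lies on a saturated chain, so it bears on this change only loosely. Among the compounds with values here, no measured step covers the aromatic change, so no shift beyond the scatter is expected in either direction. The estimated change is a 1.2-fold lower number from compound 3 to compound 4 (0.08 log units; within the scatter). For compound 4 the estimated value is 45000 nM, with an expected range from 18000 nM to 100000 nM.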

Compound 4, half-maximal inhibitory concentration: 66400 nM
Compound 4: middle estimate off by 1.5-fold (0.17 log units), on the low side; the measured number falls inside the stated range.
By their numbers in this assay, from the lowest: compounds 1 and 2 (each within the scatter of the next); then compounds 3 and 4 (each within the scatter of the next).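

In this assay, replacing methyl with methoxy on this aromatic carbon, para to a large group, gives a 1.2-fold higher number from compound 3 to compound 4 (0.09 log units; within the scatter) and so no readable change. Going by these compounds alone, the earlier compounds showed a step only on the saturated chain; this is the first reading at the aromatic position, and here the hydrogen-bond acceptor that methoxy brings leaves the number within the scatter. No evidence on the origin of this result is available.

On these data alone, whether an amine or a carboxylic acid at this carbon would move the number remains open. So does whether methoxy would behave the same way on the shorter chain of compound 2.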